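The source may hold more compounds than are shown below. What is called first, only, known or untested is meant among the compounds shown, and "the series" means these compounds.

Four compounds share one core: compound 1 `COc1cc(NC(C)CCCNC(=O)NNC(=O)Nc2cc(C(F)(F)F)cc(C(F)(F)F)c2)c2ncccc2c1`, compound 2 `COc1cc(NC(C)CCCNC(=O)NNC(=O)Nc2ccc(O)cc2)c2ncccc2c1`, compound 3 `COc1cc(NC(C)CCCNC(=O)Nc2cc(C(F)(F)F)cc(C(F)(F)F)c2)c2ncccc2c1` and compound 4 `COc1cc(NC(C)CCCNC(=O)Nc2ccc(Cl)cc2)c2ncccc2c1`, which differ only in the group carried on an amide-type nitrogen. In a functional assay on NCI-H460 cells (Homo sapiens) for inhibition, read by MTT assay, with a stated time of 72 h (on this read-out higher numbers stand for weaker inhibition and lower numbers for stronger inhibition), compound 1 gives 18000 nM and compound 3 gives 8300 nM. Compound 2 reaches only > 100000 nM, which is a limit of this assay and not a number, so compound 2 sits at the weak end of what has been seen (the limit of > 100000 nM in this assay, at which 1 of the 3 values shown sits). Compound 4 differs from compound 2 by 4-chlorophenyl in place of ((4-hydroxyphenyl)carbamoyl)amino on an amide-type nitrogen. For the measured compounds named here, no measured pair mirrors this change, so the expectation rests on compound 1 and compound 3 both giving real numbers. The step expected is an at least 3.3-fold lower number from compound 2 to compound 4 (0.52 log units; beyond the scatter), toward stronger inhibition. Compound 4 is thus estimated at 30000 nM, within 8000 nM to 100000 nM.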

Compound 4, half-maximal inhibitory concentration: 34000 nM
Beside the measured number, compound 4's estimate is 1.1-fold (0.05 log units) below it; measured number inside the range.
By their numbers in this assay, from the lowest: compound 3; then compounds 1 and 4 (each within the scatter of the next). At a limit, above all of these: compound 2.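

In this assay, for the compounds shown here, 4-chlorophenyl in place of ((4-hydroxyphenyl)carbamoyl)amino on this amide-type nitrogen gives an at least 2.9-fold lower number from compound 2 to compound 4 (0.46 log units; beyond the scatter), a single-place comparison that no earlier pair offered. Its size is only a lower bound, since compound 2 carries a limit of the assay and not a number: the limit of > 100000 nM in this assay, at which 1 of the 4 values shown sits.

The change swaps the linking atoms and the ring's substituent together, so the compounds shown cannot say which part matters. Also open, from the compounds shown here alone, is what an amine or a carboxylic acid on this nitrogen would give.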